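Benzyl to 2-Fluorophenyl on the Triazole Nitrogen

The source may report more compounds than this note shows. Statements on the series, on what has been measured and on what is new or still open speak of the compounds shown alone.

Measured so far:
compound 1 `CCCCCCC#Cc1c(CCCCCC)oc2nc(=O)n(Cc3cn(Cc4ccccc4)nn3)cc12` – 23400 nM
compound 2 `O=c1nc2oc(CCCCl)c(C#CCCCCl)c2cn1Cc1cn(-c2ccc(Cl)cc2)nn1` – > 100000 nM, a limit of the assay
compound 3 `CCCCCc1ccc(C#Cc2c(-c3ccc(CCCCC)cc3)oc3nc(=O)n(Cc4cn(Cc5ccccc5)nn4)cc23)cc1` – 73000 nM

In a functional assay on HeLa cells (Homo sapiens) for antiproliferative activity, read by MTT assay, with a stated time of 72 h (on this read-out lower numbers stand for stronger inhibition and higher numbers for weaker inhibition), compound 1 gives 23400 nM. For compound 2 the value > 100000 nM is a limit of the assay rather than a number. Compound 3 gives 73000 nM, the higher of the two numbers, with compound 1 the nearest of them and its number lying beyond the scatter below that of compound 3.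

Compound 4 `CCCCCc1ccc(C#Cc2c(-c3ccc(CCCCC)cc3)oc3nc(=O)n(Cc4cn(-c5ccccc5F)nn4)cc23)cc1` differs from compound 3 in one place: 2-fluorophenyl in place of benzyl on an aromatic nitrogen. Among the compounds with values here, no measured pair shows this change on its own, so the expected step of a 1.2-fold higher number from compound 3 to compound 4 (0.09 log units; within the scatter) is small, toward weaker inhibition or none beyond the scatter. Compound 4 is therefore estimated at 90000 nM, between 30000 nM and 200000 nM.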

Compound 4, half-maximal inhibitory concentration: 9000 nM
Beside the measured number, compound 4's estimate is 10-fold (1.00 log units) above it, outside the stated range (below it).
By their numbers in this assay, from the lowest: compound 4; then compound 1; then compound 3. At a limit, above all of these: compound 2.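

In this assay, the group on the triazole nitrogen clearly matters: putting 2-fluorophenyl in place of benzyl gives an 8.1-fold lower number from compound 3 to compound 4 (0.91 log units; beyond the scatter) and leaves the rest of the molecule unchanged. The earlier compounds shown here differ from one another in several places at once, so none of them could single out this position. Nothing measured here explains why the step runs in this direction.

The compounds shown include no plain phenyl on this nitrogen, so the part played by the fluorine stays open. From the compounds shown here alone, a phenyl ring bearing an amine or a carboxylic acid also remains untested among them.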